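The source may report more compounds than this note shows. Statements on the series, on what has been measured and on what is new or still open speak of the compounds shown alone.

Measured in a functional assay on HEK293 cells with D(4) dopamine receptor (Homo sapiens) as the target, read by FLIPR; on this read-out higher numbers stand for larger maximal responses and lower numbers for smaller maximal responses:

Compound 1 `Cc1cccc(/C(CCN2CCN(c3ccccn3)CC2)=N/O)c1`: 74%
Compound 2 `O/N=C(\CCN1CCN(c2ccccn2)CC1)c1ccc(F)cc1`: 74%

Among the compounds with values here, the one measured step, no change at the digits printed from compound 1 to compound 2 (within the scatter), swaps one substituted phenyl ring for another on the carbon that carries the double bond to nitrogen, and the maximal response does not move beyond the scatter. Compound 2 therefore stands level with compound 1; nothing in these numbers sets the two apart.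

Compound 3 `Cc1ccc(O)c(/C(CCN2CCN(c3ccccn3)CC2)=N/O)c1` is the next variation on the same carbon. Its difference from compound 2 is 2-hydroxy-5-methylphenyl in place of 4-fluorophenyl on a carbon with a double bond to nitrogen. Within the data shown here, the change again exchanges one substituted phenyl for another, so no change at the digits printed from compound 1 to compound 2 (within the scatter) is the only step that bears on it, and that step was flat. The incoming group does bring a hydrogen-bond donor and acceptor that neither earlier ring had, which the earlier step did not test, so the range should be kept wide. Still, no change beyond the scatter is the most natural expectation, and the estimated step is a number 2 percentage points lower from compound 2 to compound 3 (within the scatter). Compound 3 is expected to give 72%, within a range from 50% to 90%.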

Compound 3, largest response reached (reported as efficacy), in percent of the reference or control that the assay uses: 73%
Compound 3: middle estimate off by 1 percentage points, on the low side, within the range that was stated.
By their numbers in this assay, from the lowest: compounds 3, 1 and 2 (each within the scatter of the next).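

In this assay, the place on a carbon with a double bond to nitrogen now accepts a ring with 1 hydrogen-bond donor and 1 hydrogen-bond acceptor, which neither earlier ring had: 2-hydroxy-5-methylphenyl in place of 4-fluorophenyl gives a number 1 percentage points lower from compound 2 to compound 3 (within the scatter). The same holds for the smaller edit, hydroxy in place of hydrogen on an aromatic carbon, which gives a number 1 percentage points lower from compound 1 to compound 3 (within the scatter), so on this read-out the three compounds cannot be told apart, whichever of these substituted phenyl rings is present. No measurement is available that would explain this result.

As far as these compounds go, all three compounds carry a six-membered aromatic ring of carbon only at this place, so it remains open whether a carboxylic acid or an amine on that ring, or a cyclohexyl ring in its place, would leave the maximal response where these compounds sit. A largest response also says nothing about the concentration needed to reach it, so these values leave open whether the three compounds differ in potency at the receptor.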